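Pyridine to Phenyl on a Weak Amide Series

The compounds below may be only part of what the source reports. "The series", "measured", "known", "first", "only" and "open" are said of these compounds alone.

Compound 3 `O=C(Nc1ccc(Cl)c(-c2nnc3c(Cl)cccn23)c1)c1cccnc1Cl` sits at a limit in a functional assay on U-251 cells (Homo sapiens) for antiproliferative activity, read by MTT assay, with a stated time of 72 h (on this read-out lower numbers stand for stronger inhibition and higher numbers for weaker inhibition), giving > 100000 nM rather than a number. Compound 1 `O=C(Nc1ccc(Cl)c(-c2nnc3c(Cl)cccn23)c1)c1ccc(C(F)(F)F)cc1Cl` likewise reaches only a limit, > 100000 nM. Compound 2 `O=C(Nc1ccc(Cl)c(-c2nnc3c(Cl)cccn23)c1)c1ccccn1` gives 79000 nM. Among the compounds with values here, the only measured step that changes one place, an at least 1.2-fold higher number from compound 2 to compound 3 (0.10 log units; that floor lies within the scatter), lies within the scatter, and the limit of > 100000 nM in this assay, at which 2 of the 3 values shown sit, marks where two of the three values sit. Compound 4 `O=C(Nc1ccc(Cl)c(-c2nnc3c(Cl)cccn23)c1)c1ccccc1Cl` differs from compound 3 in one place: 2-chlorophenyl in place of 2-chloropyridin-3-yl on a carbonyl carbon. Within the data shown here, no measured step exchanges a ring with one hetero atom for a ring of carbon only, so the steps at hand give no direction. Compound 4 is therefore expected to stay weak, with an estimated step of a number no higher from compound 3 to compound 4 (the limit leaves the size open) that means little beyond the scatter. Compound 4 is estimated at 100000 nM, between 40000 nM and 300000 nM.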

Compound 4, half-maximal inhibitory concentration: > 100000 nM
Compound 4: only a limit was reported; the forecaster's own chance of this, stated with the estimate: 60%; the middle value sits exactly at the limit.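

Compound 4, with a ring of carbon only on the carbonyl carbon, also reaches only a limit, so this ring ends at the same point as the 2-chloropyridin-3-yl ring: the limit of > 100000 nM in this assay, at which 3 of the 4 values shown sit.

Within the data shown here, the one readable step is an at least 1.2-fold higher number from compound 2 to compound 4 (0.10 log units; that floor lies within the scatter). The steps to compound 4 from compound 3 and from compound 1 join two limits and cannot be read.

On these data alone, the weight of the ring hetero atom therefore stays unknown. Also open, as far as these compounds go, is whether an amine or a carboxylic acid in place of the chlorine of 2-chlorophenyl would bring a number clearly under the limit.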